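Swapping Carbamoyl for Nitrophenylsulfonyl on the Amine Nitrogen

The compounds below may be only part of what the source reports. "The series", "measured", "known", "first", "only" and "open" are said of these compounds alone.

Of the compounds shown here, three built on one shared core have been tested in a functional assay on Ehrlich cells (Mus musculus) for cytotoxicity, read by trypan blue exclusion, with a stated time of 2 h, tested at 10 ug/mL; a higher number here means a stronger effect of the compound at the concentration tested, a lower number a weaker effect. Compound 1 `N#CC1=C(N)N(c2ccc(S(N)(=O)=O)cc2)C2=C(C(=O)CCC2)C1c1ccc(Cl)cc1Cl`, which carries a free amine, gives 40%. Compound 2 `N#CC1=C(NC(=S)Nc2ccc(Cl)cc2)N(c2ccc(S(N)(=O)=O)cc2)C2=C(C(=O)CCC2)C1c1ccc(Cl)cc1Cl` gives 30%, and compound 3 `N#CC1=C(NC(N)=O)N(c2ccc(S(N)(=O)=O)cc2)C2=C(C(=O)CCC2)C1c1ccc(Cl)cc1Cl` gives 20%. Compound 3 thus holds the lowest of the three numbers, though the step of a number 10 percentage points lower from compound 2 to compound 3 (within the scatter) stays within the scatter, while the step of a number 20 percentage points lower from compound 1 to compound 3 (beyond the scatter) goes beyond it.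

Compound 4 `N#CC1=C(NS(=O)(=O)c2ccc([N+](=O)[O-])cc2)N(c2ccc(S(N)(=O)=O)cc2)C2=C(C(=O)CCC2)C1c1ccc(Cl)cc1Cl` has not yet been measured. It differs from compound 3 in a single place: (4-nitrophenyl)sulfonyl in place of carbamoyl on an amine nitrogen.

Among the compounds with values here, two measured steps touch the same amine nitrogen and therefore bear on this change. The step of a number 10 percentage points lower from compound 1 to compound 2 (within the scatter), in which a large group carrying an aromatic ring entered, lay within the scatter. The step of a number 20 percentage points lower from compound 1 to compound 3 (beyond the scatter) lowered the number modestly, and the step of a number 10 percentage points lower from compound 2 to compound 3 (within the scatter), exchanging that ring-bearing group for carbamoyl, remained within the scatter. Since the group entering in compound 4 again carries an aromatic ring, the expected step of a number 8 percentage points higher from compound 3 to compound 4 (within the scatter) is small, within the scatter, leaning slightly upward. Compound 4 is therefore estimated to give 28%, with a likely range from 15% to 45%.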

Compound 4, a percentage reported as activity, at one concentration (the size of the read-out at that concentration, not a potency): 50%
Estimate against measurement, compound 4: 22 percentage points below, outside the stated range (above it).
By their numbers in this assay, from the lowest: compounds 3, 2, 1 and 4 (each within the scatter of the next, the first and the last beyond it).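

On this amine nitrogen, a group carrying an aromatic ring does not have to keep the number low: in this assay, the exchange of carbamoyl for (4-nitrophenyl)sulfonyl brings a number 30 percentage points higher from compound 3 to compound 4 (beyond the scatter) and is the first upward step shown at this position. Within the data shown here, the presence of one six-membered aromatic ring does not settle the outcome by itself either, as the two ring-bearing groups are separated by a number 20 percentage points higher from compound 2 to compound 4 (beyond the scatter) and so differ in a way the earlier compounds could not reveal. Substitution on this nitrogen also need not cost activity, as the earlier steps might have suggested, since adding (4-nitrophenyl)sulfonyl to the free amine gives a number 10 percentage points higher from compound 1 to compound 4 (within the scatter) and leaves compound 4 and compound 1 not clearly apart.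

Nothing available explains why these groups behave differently. From the compounds shown here alone, it also remains open whether the sulfonyl link or the nitro group on the ring matters more, a question that a plain phenylsulfonyl, a methanesulfonyl or an acetyl group on the same nitrogen would help to separate.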